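A few compounds are considered here, and "the series" means these few. Any claim that something is new, unique, unknown or untested is made for them only; others in the source may bear on it.

Measured in a functional assay on HL-60 cells (Homo sapiens) for antiproliferative activity, read by CCK-8 assay, with a stated time of 72 h; on this read-out lower numbers stand for stronger inhibition and higher numbers for weaker inhibition:
- compound 1 `CC(=O)Oc1cc2c(CC[C@H](O)C(C)(C)O)c(C)ccc2cc1C(C)C`: 21700 nM
- compound 2 `CC(=O)Oc1cc2c(CC[C@H]3OC(C)(C)OC3(C)C)c(C)ccc2cc1C(C)C`: 17200 nM

For the measured compounds named here, compound 2 holds the lower of the two numbers but is not separated from the only other measured compound: a 1.3-fold lower number from compound 1 to compound 2 (0.10 log units; within the scatter), within the scatter. Compound 3 `Cc1ccc2cc(C(C)C)c(O)cc2c1CC[C@H]1OC(C)(C)OC1(C)C` carries one change: hydrogen in place of acetyl on an oxygen on an aromatic ring, which reads as acetoxy to hydroxy. Going by the values given here, the single measured step lies on a saturated chain carbon, not on this oxygen, so no measured step covers this change directly. In this assay, no shift beyond the scatter is therefore expected: the estimated step is a 1.4-fold lower number from compound 2 to compound 3 (0.16 log units; within the scatter). For compound 3 the estimated value is 12000 nM, with an expected range of 4000 nM to 32000 nM.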

Compound 3, half-maximal inhibitory concentration: 49400 nM
For compound 3 the middle estimate is 4.1-fold (0.61 log units) below the measured one; measured number above the stated range.
By their numbers in this assay, from the lowest: compounds 2 and 1 (each within the scatter of the next); then compound 3.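

Changes on the aromatic oxygen move the number more than the chain change does: in this assay, the acetoxy to hydroxy change gives a 2.9-fold higher number from compound 2 to compound 3 (0.46 log units; beyond the scatter), a modest shift, whereas the chain change gives a 1.3-fold lower number from compound 1 to compound 2 (0.10 log units; within the scatter). With the 2,2,5,5-tetramethyl-1,3-dioxolan-4-yl chain in place, the acetyl-bearing compound 2 therefore reads as the stronger inhibitor, and compound 3 gives 49400 nM. Nothing available accounts for this shift.

As far as these compounds go, it remains open whether the same loss appears with the 1,2-dihydroxy-2-methylpropyl chain. From the compounds shown here alone, how a methyl ether or a longer acyl group such as propanoyl would read on this oxygen also remains open.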